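Acetyl to Dimethylamino: What to Expect for Compound 4

The compounds below may be only part of what the source reports. "The series", "measured", "known", "first", "only" and "open" are said of these compounds alone.

Compound 1 `COc1cc(C)cc(-c2c(-c3ccnc(-c4ccc(C(C)=O)cc4)c3)cnn2CC#N)c1` gives 3700 nM
Compound 2 `COc1cc(C)cc(-c2nn(CC#N)cc2-c2ccc(-c3cccc(C(C)=O)c3)nc2)c1` gives 4130 nM
Compound 3 `Cc1cc(O)cc(-c2nn(CC#N)cc2-c2ccnc(-c3ccc(N(C)C)cc3)c2)c1` gives 4130 nM

All three numbers come from a functional assay on COLO 205 cells (Homo sapiens) for inhibition, read by sulforhodamine B assay, with a stated time of 48 h; on this read-out lower numbers stand for stronger inhibition of growth and higher numbers for weaker inhibition of growth. Compound 1 sits within the usual scatter of both compound 2 and compound 3, so the three measured compounds are, for practical purposes, indistinguishable on this read-out. Going by the values given here, no pair among them differs in only one place, so no single-change step is available to lean on.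

Compound 4 `COc1cc(C)cc(-c2c(-c3ccnc(-c4ccc(N(C)C)cc4)c3)cnn2CC#N)c1` has not yet been measured. It differs from compound 1 in one place: dimethylamino in place of acetyl on an aromatic carbon. Put plainly, dimethylamino replaces acetyl on an aromatic carbon of the outer phenyl ring, and the rest of the molecule stays as it is.

Compound 3 already carries a dimethylamino group on its outer phenyl ring, though it differs from compound 4 elsewhere as well, and its value lies within the scatter of compound 1. On that basis compound 4 is expected to land close to compound 1, and the step of a 1.1-fold higher number from compound 1 to compound 4 (0.03 log units; within the scatter) is estimated to be no larger than the scatter, in no clear direction. The estimate for compound 4 is therefore 4000 nM, with a plausible range from 1500 nM to 10000 nM.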

Compound 4, concentration for total growth inhibition: > 100000 nM
Compound 4 was reported as a limit; the forecaster's own chance of this, stated with the estimate: 5%; at least 25-fold (1.39 log units) between middle value and limit.
By their numbers in this assay, from the lowest: compounds 1, 2 and 3 (each within the scatter of the next). At a limit, above all of these: compound 4.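

In this assay, replacing acetyl with dimethylamino on the outer phenyl ring gives an at least 27-fold higher number from compound 1 to compound 4 (1.43 log units; beyond the scatter). Going by these compounds alone, this single-change pair shows that growth inhibition depends strongly on the group at this place, para to a large group, something the earlier compounds could not show, as no two of them differ in only one place. For compound 4, the reported > 100000 nM is a limit of the assay and not a number: the limit of > 100000 nM in this assay, at which 1 of the 4 values shown sits.

The counts printed for the two groups do not separate them: acetyl and dimethylamino have the same number of heavy atoms and of hydrogen-bond acceptors, and neither carries a net charge. Matching these counts was therefore not enough to keep the value of compound 1, although the groups still differ in their atoms and in the double bond of acetyl.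

Going by these compounds, whether the result reflects losing acetyl or gaining dimethylamino stays open, with only this one replacement in view at this place. A primary amine, a carboxylic acid or a longer ketone such as propionyl at the same carbon would help separate those two readings.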